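A few compounds are considered here, and "the series" means these few. Any claim that something is new, unique, unknown or untested is made for them only; others in the source may bear on it.

Measured compounds:
Compound 1 `C#CCNC1CCc2c(SCc3cccc(F)c3)cccc21`: 11600 nM
Compound 2 `C#CCNC1CCc2c(SCCc3cccc(F)c3)cccc21`: 7810 nM
Compound 3 `C#CCNC1CCc2c(SCCc3cccc(OC)c3)cccc21`: 3820 nM

All three were run in an ADME assay on isolated protein for inhibition of Amine oxidase [flavin-containing] B (Homo sapiens); a lower number here means a stronger inhibitor, a higher number a weaker inhibitor. Compound 1 carries the highest number of the three; its gap to compound 2 is within the scatter, while its gap to compound 3 is beyond it. Among the measured compounds shown here, the only step measured in this set is a 2.0-fold lower number from compound 2 to compound 3 (0.31 log units; beyond the scatter), a modest one.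

Compound 4 `C#CCNC1CCc2c(SCc3cccc(Cl)c3)cccc21` differs from compound 1 by chloro in place of fluoro on an aromatic carbon. For the measured compounds named here, no measured pair swaps these two halogens; the methoxy-for-fluoro step is the sole guide for a change at this aromatic carbon and is itself small. The expected step in this assay is therefore a 1.7-fold lower number from compound 1 to compound 4 (0.22 log units; within the scatter), not clearly beyond the scatter.

Compound 4 is estimated at 7000 nM, with a range of 3000 nM to 16000 nM.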

Compound 4, half-maximal inhibitory concentration: 1090 nM
Compound 4: middle estimate off by 6.4-fold (0.81 log units), on the high side; measured number outside the range, below it.
By their numbers in this assay, from the lowest: compound 4; then compound 3; then compounds 2 and 1 (each within the scatter of the next).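

In this assay the change from 3-fluorophenyl to 3-chlorophenyl gives an 11-fold lower number from compound 1 to compound 4 (1.03 log units; beyond the scatter) and so shows that a single halogen swap on this aromatic carbon can move the number much further than the modest 2.0-fold lower number from compound 2 to compound 3 (0.31 log units; beyond the scatter) had suggested. That earlier step stands on a different chain, so the two steps do not share a background. No measured evidence accounts for the size of the new step.

Still open, from the compounds shown here alone, is whether chloro in place of fluoro gives a step of similar size on the chain of compound 2. Going by these compounds, how bromo or trifluoromethyl would fare on this same aromatic carbon also remains open.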